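The source may hold more compounds than are shown below. What is called first, only, known or untested is meant among the compounds shown, and "the series" means these compounds.

Among the three compounds measured so far, compound 3 `CCCCCCCCCCCC(=O)OC[C@H](CSC[C@@H](N)C(=O)NCCOCCOS(=O)(=O)O)OC(=O)CCCCCCCCCCC` stands lowest: in an assay on HEK293 cells for agonist activity at Toll-like receptor 2 (Homo sapiens) (on this read-out higher numbers stand for an effect only at larger amounts of compound and lower numbers for an effect already at smaller amounts), compound 3 gives 61 nM. Compound 1 `CCCCCCCCCCCC(=O)OC[C@H](CSC[C@@H](N)C(=O)NC1(CO)CC1)OC(=O)CCCCCCCCCCC` gives 265 nM, and compound 2 `CCCCCCCCCCCC(=O)OC[C@H](CSC[C@@H](N)C(=O)NCCCS(=O)(=O)O)OC(=O)CCCCCCCCCCC` gives 5560 nM. Both gaps are beyond the scatter, so compound 3 is the most potent of the three, with a 4.3-fold lower number from compound 1 to compound 3 (0.64 log units; beyond the scatter) and a 91-fold lower number from compound 2 to compound 3 (1.96 log units; beyond the scatter).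

Compound 4 `CCCCCCCCCCCC(=O)OC[C@H](CSC[C@@H](N)C(=O)NC(C)c1ccccc1)OC(=O)CCCCCCCCCCC` differs from compound 3 in one place: 1-phenylethyl in place of 2-(2-(sulfooxy)ethoxy)ethyl on an amide-type nitrogen. The 1-phenylethyl group brings no hydrogen-bond donors or acceptors, where the group it replaces carried several.

The measured steps that bear on this all concern the same amide-type nitrogen. Going from the small 1-(hydroxymethyl)cyclopropyl group to the 2-(2-(sulfooxy)ethoxy)ethyl group gave a 4.3-fold lower number from compound 1 to compound 3 (0.64 log units; beyond the scatter), whereas swapping in 3-sulfopropyl gave a 21-fold higher number from compound 1 to compound 2 (1.32 log units; beyond the scatter). For the measured compounds named here, no measured compound carries an aromatic group at this position, so the expectation rests on the observation that the 2-(2-(sulfooxy)ethoxy)ethyl group of compound 3 is the only one to bring the number down beyond the scatter. Removing it is therefore expected to raise the number, by a step on the order of a 4.9-fold higher number from compound 3 to compound 4 (0.69 log units; beyond the scatter), with wide uncertainty.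

For compound 4 the estimate in this assay is 300 nM, with a likely range from 60 nM to 1500 nM.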

Compound 4, half-maximal effective concentration: 9900 nM
The estimate for compound 4 lay 33-fold (1.52 log units) below the measured number, outside the stated range (above it).
By their numbers in this assay, from the lowest: compound 3; then compound 1; then compounds 2 and 4 (each within the scatter of the next).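

In this assay, putting 1-phenylethyl in place of 2-(2-(sulfooxy)ethoxy)ethyl on the amide-type nitrogen gives a 160-fold higher number from compound 3 to compound 4 (2.21 log units; beyond the scatter) and shows that a group with one six-membered aromatic ring of carbon only, and with 0 hydrogen-bond donors and 0 hydrogen-bond acceptors, can sit at the high end of the numbers at this position. Compared with the 1-(hydroxymethyl)cyclopropyl group, the same change gives a 37-fold higher number from compound 1 to compound 4 (1.57 log units; beyond the scatter) as a large step, while replacing 3-sulfopropyl gives only a 1.8-fold higher number from compound 2 to compound 4 (0.25 log units; within the scatter) and leaves those two compounds within the scatter, so two quite different groups cannot be told apart here. No supporting measurement is available to explain these steps.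

The compounds shown leave open whether the low number of compound 3 depends on its sulfooxy end, which a 2-(2-hydroxyethoxy)ethyl group would test. They also leave open whether a benzyl group, which lacks the branching methyl of 1-phenylethyl, or a carboxylic acid on a short chain would give a number closer to that of compound 3 or compound 4.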